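The source may report more compounds than this note shows. Statements on the series, on what has been measured and on what is new or still open speak of the compounds shown alone.

Compound 1, `C/C(=N/NC(=O)C(C#N)C(=S)S)c1ccc(NS(=O)(=O)c2ccc(C)cc2)cc1`, gives 5000 nM in a functional assay on HepG2 cells (Homo sapiens) for cytotoxicity, read by ELISA, with stated times of 2 h and 48 h (on this read-out higher numbers stand for weaker inhibition and lower numbers for stronger inhibition), the lowest of the two numbers in hand; compound 2, `C/C(=N/n1c(N)c(C#N)c(-c2ccc([N+](=O)[O-])cc2)c(C#N)c1=O)c1ccc(NS(=O)(=O)c2ccc(C)cc2)cc1`, gives 23500 nM in this assay, a gap beyond the usual scatter. The unmeasured compound 3, `C/C(=N/NC(=O)c1sc2c(c1N)CCCC2)c1ccc(NS(=O)(=O)c2ccc(C)cc2)cc1`, differs from compound 1 by a single change: a group of 10 heavy atoms (8 carbon, 1 nitrogen, 1 sulfur; one five-membered aromatic ring with 1 hetero atom, one six-membered non-aromatic ring of carbon only) in place of a group of 6 heavy atoms (3 carbon, 1 nitrogen, 2 sulfur; no ring), on a carbonyl carbon. Going by the values given here, no measured pair shows this kind of change, so its effect can only be guessed. The step from compound 1 to compound 3 is expected to be small, perhaps toward a slightly higher number, with a 1.6-fold higher number from compound 1 to compound 3 (0.20 log units; within the scatter). Compound 3 is therefore estimated at 8000 nM, in a range from 2000 nM to 40000 nM.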

Compound 3, half-maximal inhibitory concentration: 20000 nM
Beside the measured number, compound 3's estimate is 2.5-fold (0.40 log units) below it; the range from low to high includes it.
By their numbers in this assay, from the lowest: compound 1; then compounds 3 and 2 (each within the scatter of the next).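

In this assay, the group on a carbonyl carbon whose other neighbour is an amide-type nitrogen proves able to move the number: the ring-bearing group of 10 heavy atoms, in place of the ring-free group of 6 heavy atoms, gives a 4.0-fold higher number from compound 1 to compound 3 (0.60 log units; beyond the scatter) and so lies beyond the scatter. Of this pair, the ring-free group holds the lower number. No measurement in hand accounts for the step. Going by these compounds, it remains open how a simple amine or a short ethyl chain on this carbonyl carbon would read, and whether the thiophene ring or the carbocycle fused to it matters more.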